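This account rests on a few compounds, and the source may have more. Where it says the series, first, only, none or still open, it means among the compounds named here.

Measured compounds in a functional assay on HepG2 cells (Homo sapiens) for antiproliferative activity, read by MTT assay, with a stated time of 48 h; on this read-out higher numbers stand for weaker inhibition and lower numbers for stronger inhibition:

Compound 1 `Fc1ccc(N2CCN(Cn3nc(-c4ccc5c(c4)OCCO5)oc3=S)CC2)cc1` gives only the assay limit > 50000 nM.
Compound 2 `COc1cccc(N2CCN(Cn3nc(-c4ccc5c(c4)OCCO5)oc3=S)CC2)c1` gives 21400 nM.
Compound 3 `S=c1oc(-c2ccc3c(c2)OCCO3)nn1CN1CCN(c2ccccc2Cl)CC1` gives 11400 nM.

Compound 3 holds the lowest of the two numbers on this assay, but its gap to compound 2, a 1.9-fold lower number from compound 2 to compound 3 (0.27 log units; within the scatter), sits within the scatter, so no order between these two can be claimed. Against compound 1 the steps of an at least 2.3-fold lower number from compound 1 to compound 2 (0.36 log units; beyond the scatter) and an at least 4.3-fold lower number from compound 1 to compound 3 (0.64 log units; beyond the scatter) are bounds only, since compound 1 sits at the limit of > 50000 nM in this assay, at which 1 of the 3 values shown sits.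

Compound 4 `S=c1oc(-c2ccc3c(c2)OCCO3)nn1CN1CCN(c2ccccc2)CC1` differs from compound 3 by hydrogen in place of chloro on an aromatic carbon. For the measured compounds named here, all three measured steps change the aryl group on the amine nitrogen in the ring, and the one step between two real numbers, a 1.9-fold lower number from compound 2 to compound 3 (0.27 log units; within the scatter), is within the scatter. Swapping the aryl substitution pattern has therefore shown at most a modest effect where it can be read, so a small step is expected here, if anything toward a higher number on loss of the chloro.

Compound 4 is estimated at 16000 nM, with a range of 6000 nM to 45000 nM, meaning an expected step of a 1.4-fold higher number from compound 3 to compound 4 (0.15 log units; within the scatter).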

Compound 4, half-maximal inhibitory concentration: > 50000 nM
Compound 4 was reported as a limit; the forecaster's own chance of this, stated with the estimate: 20%; at least 3.1-fold (0.49 log units) between middle value and limit.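

In this assay, the aryl group on the amine nitrogen in the ring now shows a change that can be read beyond the scatter: an at least 4.3-fold higher number from compound 3 to compound 4 (0.64 log units; beyond the scatter) with hydrogen in place of chloro, and an at least 2.3-fold higher number from compound 2 to compound 4 (0.36 log units; beyond the scatter) with hydrogen in place of methoxy. Among the listed compounds, the lower numbers thus go with the 2-chlorophenyl and 3-methoxyphenyl groups rather than plain phenyl, though compound 1, with its 4-fluorophenyl group, goes against any general benefit of a substituent, and its step to compound 4 cannot be read. The result for compound 4 is a limit, so both readable steps are bounds only: the limit of > 50000 nM in this assay, at which 2 of the 4 values shown sit.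

Still open, from the compounds shown here alone, is whether a methyl, a trifluoromethyl or an amine in place of the chloro in the 2-chlorophenyl group would keep a number close to that of compound 3. Going by these compounds, the true size of the steps to compound 4 also remains open.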